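The compounds below may be only part of what the source reports. "The series", "measured", "known", "first", "only" and "open" are said of these compounds alone.

Measured compounds in a functional assay on CHO cells for agonist activity at Melanocortin receptor 3 (Homo sapiens), read by cAMP accumulation; on this read-out lower numbers stand for an effect already at smaller amounts and higher numbers for an effect only at larger amounts of compound:
- compound 1, `CC(=O)N(CC(C1CCCCC1)N1CCN(C(=O)[C@@H]2CN(C(C)(C)C)C[C@H]2c2ccc(F)cc2F)CC1)C(C)C`: 2000 nM
- compound 2, `CC(C)N(CC(C1CCCCC1)N1CCN(C(=O)[C@@H]2CN(C(C)(C)C)C[C@H]2c2ccc(F)cc2F)CC1)S(C)(=O)=O`: 1800 nM
- compound 3, `CC(C)N(CC(C1CCCCC1)N1CCN(C(=O)[C@@H]2CN(C(C)(C)C)C[C@H]2c2ccc(F)cc2F)CC1)C(=O)c1cccnn1`: 90 nM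

Compound 3 gives the lowest number of the three in this assay. The steps that set it apart are a 22-fold lower number from compound 1 to compound 3 (1.35 log units; beyond the scatter) and a 20-fold lower number from compound 2 to compound 3 (1.30 log units; beyond the scatter), both large and well beyond the scatter. By contrast a 1.1-fold lower number from compound 1 to compound 2 (0.05 log units; within the scatter) is within the scatter, so the acetyl and methylsulfonyl groups on the amine nitrogen cannot be told apart on these numbers.

Compound 4, `CC(C)N(CC(C1CCCCC1)N1CCN(C(=O)[C@@H]2CN(C(C)(C)C)C[C@H]2c2ccc(F)cc2F)CC1)C(=O)c1cnn(C(C)C)c1`, is not yet measured. Its difference from compound 3 is 1-isopropyl-1H-pyrazol-4-yl in place of pyridazin-3-yl on a carbonyl carbon. No measured step bears on an exchange of one aromatic ring for another at this position: the two large steps shown compare an aromatic acyl group against a small non-aromatic group on the amine nitrogen, and there is no pair in which two different aromatic rings are compared. The only safe inference is that an aromatic ring on the carbonyl carbon is retained in compound 4.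

Compound 4 is therefore expected to stay near compound 3 in this assay, with a 1.7-fold higher number from compound 3 to compound 4 (0.22 log units; within the scatter) as the estimated step. Compound 4 is estimated at 150 nM, within a range of 50 nM to 500 nM.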

Compound 4, half-maximal effective concentration: 79 nM
The estimate for compound 4 lay 1.9-fold (0.28 log units) above the measured number; measured number inside the range.
By their numbers in this assay, from the lowest: compounds 4 and 3 (each within the scatter of the next); then compounds 2 and 1 (each within the scatter of the next).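

In this assay, among the compounds shown here, this is the first comparison of two aromatic rings on the carbonyl carbon, and a 1.1-fold lower number from compound 3 to compound 4 (0.06 log units; within the scatter) shows that a five-membered aromatic ring with 2 hetero atoms and a six-membered one cannot be told apart here, although 1-isopropyl-1H-pyrazol-4-yl brings 8 heavy atoms against 6 for pyridazin-3-yl. The low number is therefore not unique to pyridazin-3-yl: there is a 23-fold lower number from compound 2 to compound 4 (1.36 log units; beyond the scatter) on exchanging methylsulfonyl for (1-isopropyl-1H-pyrazol-4-yl)carbonyl on the amine nitrogen, and a 25-fold lower number from compound 1 to compound 4 (1.40 log units; beyond the scatter) on exchanging methyl for 1-isopropyl-1H-pyrazol-4-yl on the carbonyl carbon, so both aromatic acyl compounds stand well clear of the two with small non-aromatic groups. No supporting data bear on why the two rings give such similar numbers.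

The compounds shown leave open whether the isopropyl group on the pyrazole matters, a question that the unsubstituted 1H-pyrazol-4-yl or its 1-methyl analogue would address. Also open, going by these compounds, is whether a ring on the carbonyl carbon must be aromatic at all, which cyclohexyl or piperidin-4-yl in place of the aromatic ring would test.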